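The source may report more compounds than this note shows. Statements on the series, on what has been measured and on what is new or still open speak of the compounds shown alone.

Measured compounds:
Compound 1 `Cc1ccc(Oc2c(/C=N\OCc3c(Cl)c(-c4ccc(F)cc4)nn3C)c(C)nn2C)cc1`: 80%
Compound 2 `COc1ccc(Oc2c(/C=N\OCc3c(Cl)c(-c4ccc(F)cc4)nn3C)c(C)nn2C)cc1`: 80%
Compound 3 `CCc1nn(C)c(CO/N=C/c2c(C)nn(C)c2Oc2ccccc2C)c1Cl`: < 80%

The study measured these compounds in a functional assay on SMMC-7721 cells (Homo sapiens) for inhibition, read by MTT assay, with a stated time of 72 h, tested at 25 uM; a higher number here means more inhibition at the concentration tested (going by the name of the read-out), a lower number less inhibition. Compound 1 gives 80% there, and compound 2 gives 80%. The step between them, no change at the digits printed from compound 1 to compound 2 (within the scatter), follows from the change (methoxy in place of methyl on an aromatic carbon). For compound 3 the assay gives only a limit, < 80%, a limit of the assay and not a number; this is the case described by the limit of < 80% in this assay, at which 1 of the 3 values shown sits. The cores of compound 1 and compound 3 differ in more than one place, and the difference between the two cores is not broken down here.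

Compound 4 `CCc1nn(C)c(CO/N=C/c2c(C)nn(C)c2Oc2ccccc2OC)c1Cl` has not been measured. It stands to compound 3 as compound 2 stands to compound 1: the change is methoxy in place of methyl on an aromatic carbon. Going by the values given here, it is the same kind of change as the one from compound 1 to compound 2, but not the same, for the new group sits para to a large group in the first pair and ortho to a large group in the second.

In this assay the step from compound 3 to compound 4 is expected to be a step that the limit leaves unreadable from compound 3 to compound 4, resting on the earlier step of no change at the digits printed from compound 1 to compound 2 (within the scatter), which stayed within the scatter. Compound 4 is therefore estimated at 50%, between 15% and 79%, and it is expected that the assay may again report only a limit for compound 4.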

Compound 4, a percentage reported as inhibition, at one concentration (the size of the read-out at that concentration, not a potency): < 80%
Compound 4: only a limit was reported; the forecaster's own chance of this, stated with the estimate: 70%; the middle value lies beyond the limit too.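

In this assay compound 4 gives < 80% as a limit of the assay and not a number. Compound 3 likewise has only a limit, so no step can be read between compound 3 and compound 4: the limit of < 80% in this assay, at which 2 of the 4 values shown sit. The compounds shown leave open whether methoxy in place of methyl, ortho to a large group, alters inhibition at all.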